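A few compounds are considered here, and "the series" means these few. Any claim that something is new, unique, unknown or untested is made for them only; others in the source may bear on it.

Measured so far:
- compound 1 `COc1cc(-c2ccnc3cc(-c4ccccc4)nn23)cc(OC)c1OC`; in a functional assay on B16-F0 cells (Mus musculus) for inhibition, read by CCK-8 assay, with a stated time of 48 h (a higher number here means a weaker inhibitor, a lower number a stronger inhibitor), compound 1 gives 4730 nM
- compound 2 `COc1ccc(-c2cc3nccc(-c4cc(OC)c(OC)c(OC)c4)n3n2)cc1`; in this assay compound 2 gives 1410 nM
- compound 3 `COc1cc(-c2ccnc3cc(-c4ccc(F)cc4)nn23)cc(OC)c1OC`; in this assay compound 3 gives 4540 nM

Compound 3 stands second highest of the three numbers: it sits beside compound 1 (a 1.0-fold lower number from compound 1 to compound 3 (0.02 log units; within the scatter)) and apart from compound 2 (a 3.2-fold higher number from compound 2 to compound 3 (0.51 log units; beyond the scatter)).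

The next compound, compound 4 `COc1cc(-c2ccnc3cc(-c4ccc(C)c(C)c4)nn23)cc(OC)c1OC`, is not yet measured. Its change from compound 3: 3,4-dimethylphenyl in place of 4-fluorophenyl on an aromatic carbon.

All three measured steps bear on this position of the phenyl ring. a 3.4-fold lower number from compound 1 to compound 2 (0.53 log units; beyond the scatter). a 1.0-fold lower number from compound 1 to compound 3 (0.02 log units; within the scatter). a 3.2-fold higher number from compound 2 to compound 3 (0.51 log units; beyond the scatter). So a methoxy here brought a modest gain, a fluoro brought nothing beyond the scatter, and nothing among the measured compounds carries two methyl groups at this ring. The closest guide is that a hydrogen and a fluoro lie within the scatter of each other, while only the methoxy moved the number. For compound 4 the expectation in this assay is therefore a step no larger than modest and, if anything, toward a lower number: a 1.5-fold lower number from compound 3 to compound 4 (0.18 log units; within the scatter), with the possibility of no step beyond the scatter kept open.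

Compound 4 is estimated at 3000 nM, with a range from 1200 nM to 7500 nM.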

Compound 4, half-maximal inhibitory concentration: 391 nM
Compound 4: middle estimate off by 7.7-fold (0.88 log units), on the high side; measured number below the stated range.
By their numbers in this assay, from the lowest: compound 4; then compound 2; then compounds 3 and 1 (each within the scatter of the next).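

In this assay, the 3,4-dimethylphenyl group gives the largest steps yet seen at this position (a 12-fold lower number from compound 3 to compound 4 (1.06 log units; beyond the scatter)) and (a 12-fold lower number from compound 1 to compound 4 (1.08 log units; beyond the scatter)), so a site that showed no difference between phenyl and 4-fluorophenyl can still respond strongly to a change in the aryl group. The methoxy step is no longer the ceiling here (a 3.6-fold lower number from compound 2 to compound 4 (0.56 log units; beyond the scatter)), which makes compound 4 the most potent of the four, with compound 2 next and compounds 1 and 3 within the scatter of each other. Nothing in the data explains the gain from the two methyl groups.

As far as these compounds go, it remains open whether a single methyl group on the phenyl ring would carry the step or whether both methyl groups are needed. From the compounds shown here alone, it is also open whether larger carbon groups such as ethyl or isopropyl, or a chloro, an amine or a carboxylic acid on this ring, would hold, extend or lose the gain, and whether it would persist with other changes to the shared core.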